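The source may hold more compounds than are shown below. What is called first, only, known or untested is meant among the compounds shown, and "the series" means these compounds.

Measured compounds:
Compound 1, `COc1ccc(NC(=O)c2cc(Oc3ccc(/C=C/c4ccccn4)cc3)ccn2)cc1`, gives 20000 nM in a functional assay on A549 cells (Homo sapiens) for antiproliferative activity, read by CCK-8 assay, with a stated time of 48 h; a lower number here means a stronger inhibitor, a higher number a weaker inhibitor.
Compound 2, `O=C(Nc1ccc(Cl)cc1)c1cc(Oc2ccc(/C=C/c3ccccn3)cc2)ccn1`, gives 16200 nM in this assay.

Compound 2 and compound 1 cannot be told apart on these numbers, since a 1.2-fold lower number from compound 1 to compound 2 (0.09 log units; within the scatter). Compound 3, `O=C(NCc1ccccc1)c1cc(Oc2ccc(/C=C/c3ccccn3)cc2)ccn1`, has not yet been measured. It differs from compound 2 in one place: benzyl in place of 4-chlorophenyl on an amide-type nitrogen. Going by the values given here, the only measured step, a 1.2-fold lower number from compound 1 to compound 2 (0.09 log units; within the scatter), exchanges one substituent on the aromatic ring of the amide while leaving the aryl amide itself untouched, so it does not speak to the exchange of the whole 4-chlorophenyl for benzyl. Among the compounds with values here, the data give no measured step that bears directly on this change, and both measured compounds sit close together. Compound 3 is therefore expected to land near compound 2, with an expected step of a 1.1-fold higher number from compound 2 to compound 3 (0.05 log units; within the scatter), in no firm direction. The estimate for compound 3 is 18000 nM, between 5000 nM and 60000 nM.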

Compound 3, half-maximal inhibitory concentration: 18800 nM
Compound 3: middle estimate off by 1.0-fold (0.02 log units), on the low side; measured number inside the range.
By their numbers in this assay, from the lowest: compounds 2, 3 and 1 (each within the scatter of the next).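

In this assay, benzyl in place of 4-chlorophenyl on the amide-type nitrogen gives a 1.2-fold higher number from compound 2 to compound 3 (0.06 log units; within the scatter) and benzyl in place of 4-methoxyphenyl on that nitrogen gives a 1.1-fold lower number from compound 1 to compound 3 (0.03 log units; within the scatter) as the second reading of this position. The earlier pair showed only an exchange of one substituent on the aromatic ring, whereas these steps show that exchanging the whole group on this nitrogen also gives no readable difference among the three compounds. Nothing available accounts for this result.

The compounds shown leave open whether a group of another kind on this nitrogen, such as a longer chain like phenethyl or a chain carrying an amine, would give a step beyond the scatter. They also leave open whether a carboxylic acid or an amine placed on the shared core would move the number at all.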